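The compounds below may be only part of what the source reports. "The series", "measured", "known", "first", "only" and "open" are said of these compounds alone.

Measured in a functional assay on VCaP cells (Homo sapiens) for antiproliferative activity, read by fluorescence and propidium iodide staining, with a stated time of 96 h (on this read-out lower numbers stand for stronger inhibition and higher numbers for weaker inhibition), so far:
compound 1 `O=C(Nc1ccc([N+](=O)[O-])c(C(F)(F)F)c1)c1ccc(Sc2ccc(O)cc2)cc1` gives 5190 nM
compound 2 `O=C(Nc1cc(C(F)(F)F)cc(C(F)(F)F)c1)c1ccc(Sc2ccc(O)cc2)cc1` gives 2590 nM
compound 3 `O=C(Nc1cc(C(F)(F)F)ccc1C(F)(F)F)c1ccc(Sc2ccc(O)cc2)cc1` gives 10900 nM

Compound 1 lies within the scatter of compound 2, while compound 3 carries a higher number, beyond the scatter from compound 1. Compound 4 `O=C(Nc1cccc(C(F)(F)F)c1)c1ccc(Sc2ccc(O)cc2)cc1` differs from compound 1 by hydrogen in place of nitro on an aromatic carbon, ortho to a trifluoromethyl group hydrogen in place of nitro on an aromatic carbon in this one place. For the measured compounds named here, no measured pair isolates this change. Compound 1 at 5190 nM and compound 2 at 2590 nM bear different groups yet sit within the scatter, so no step beyond the scatter is expected in this assay here. The expected step is a 1.0-fold lower number from compound 1 to compound 4 (0.02 log units; within the scatter) and this stays within the scatter. For compound 4 the estimated value is 5000 nM with an expected range from 2000 nM to 13000 nM at its upper end.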

Compound 4, half-maximal inhibitory concentration: 10600 nM
For compound 4 the middle estimate is 2.1-fold (0.33 log units) below the measured one; measured number inside the range.
By their numbers in this assay, from the lowest: compounds 2 and 1 (each within the scatter of the next); then compounds 4 and 3 (each within the scatter of the next).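

In this assay, for the compounds shown here, hydrogen in place of nitro, ortho to a trifluoromethyl group, produces a modest step beyond the scatter (a 2.0-fold higher number from compound 1 to compound 4 (0.31 log units; beyond the scatter)), so the nitro group counts at this position, which no earlier pair could show. Hydrogen in place of trifluoromethyl gives two different outcomes, a modest step in one case (a 4.1-fold higher number from compound 2 to compound 4 (0.61 log units; beyond the scatter)) and none beyond the scatter in the other (a 1.0-fold lower number from compound 3 to compound 4 (0.01 log units; within the scatter)). No measurement at hand explains these steps. The compounds shown leave open whether an amine or a nitrile at this position would perform like nitro or like hydrogen.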